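Trifluoromethyl for chloro on the urea aryl of compound 1

This account rests on a few compounds, and the source may have more. Where it says the series, first, only, none or still open, it means among the compounds named here.

Compound 1 `COc1cc(-c2nn(-c3cccc(NC(=O)Nc4ccc(Cl)c(Cl)c4)c3)cc2-c2ccncc2)ccc1Cl` is measured in a functional assay on A498 cells (Homo sapiens) for inhibition, read by sulforhodamine B assay, with a stated time of 48 h (a higher number here means a weaker inhibitor, a lower number a stronger inhibitor), and gives 1140 nM. Among the three numbers, compound 1 stands highest, yet its gap to compound 2 `O=C(Nc1cccc(-n2cc(-c3ccncc3)c(-c3ccc(Cl)c(O)c3)n2)c1)Nc1ccc(Cl)c(Cl)c1` and to compound 3 `O=C(Nc1cccc(-n2cc(-c3ccncc3)c(-c3ccc(Cl)c(O)c3)n2)c1)Nc1cc(C(F)(F)F)cc(C(F)(F)F)c1` lies within the scatter of this assay. Compound 2 gives 940 nM and compound 3 gives 790 nM in this assay. Within the data shown here, the one single-point step in the set, a 1.2-fold lower number from compound 1 to compound 2 (0.08 log units; within the scatter), concerns the methoxy on the shared core and is within the scatter.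

Compound 4 `COc1cc(-c2nn(-c3cccc(NC(=O)Nc4ccc(Cl)c(C(F)(F)F)c4)c3)cc2-c2ccncc2)ccc1Cl` is not yet measured. It differs from compound 1 by trifluoromethyl in place of chloro on an aromatic carbon. Among the measured compounds shown here, no measured step varies this position alone; the closest comparison is between compound 2 and compound 3, which differ in the urea aryl and show numbers close to each other. Hence no step beyond the scatter is expected in this assay, in either direction. The expected step from compound 1 is a 1.1-fold lower number from compound 1 to compound 4 (0.06 log units; within the scatter). Compound 4 is estimated at 1000 nM, within a range of 450 nM to 2300 nM.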

Compound 4, half-maximal inhibitory concentration: 840 nM
Estimate against measurement, compound 4: 1.2-fold (0.08 log units) above; the range from low to high includes it.
By their numbers in this assay, from the lowest: compounds 3, 4, 2 and 1 (each within the scatter of the next).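

In this assay the change from 3,4-dichlorophenyl to 4-chloro-3-(trifluoromethyl)phenyl gives a 1.4-fold lower number from compound 1 to compound 4 (0.13 log units; within the scatter) with the rest of compound 1 held fixed. Among these compounds, this is the only reading of this position alone: at this place, trifluoromethyl can stand in for chloro, four heavy atoms for one, with no step beyond the scatter. Nothing shown bears on why the number holds across this change.

No step shown at this position lies beyond the scatter, so how far the number can move here remains unknown. Also open, going by these compounds, are whether an amine, a carboxylic acid or a longer chain in place of the chloro would give such a step, and whether trifluoromethyl for chloro reads the same on the hydroxy core of compound 2.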